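Isopropyl for Trifluoromethyl: Solubility Outlook for Compound 3

A few compounds are considered here, and "the series" means these few. Any claim that something is new, unique, unknown or untested is made for them only; others in the source may bear on it.

Compound 1, `CNC(=O)c1cc(Oc2ccc3nc(Nc4cccc(C(C)(C)C)c4)ncc3c2)ccn1`, gives < 1000 nM in a physicochemical assay for solubility, at pH 7 (a higher number here means a more soluble compound, a lower number a less soluble compound), a limit of the assay rather than a number.
Compound 2, `CNC(=O)c1cc(Oc2ccc3nc(Nc4cccc(C(F)(F)F)c4)ncc3c2)ccn1`, gives < 1000 nM in this assay, again a limit.

Both compounds thus sit at the limit of < 1000 nM in this assay, at which 2 of the 2 values shown sit, and the step that the two limits leave unreadable from compound 1 to compound 2 cannot be read. Compound 2 therefore stands only at that limit, with no number of its own. Compound 3, `CNC(=O)c1cc(Oc2ccc3nc(Nc4cccc(C(C)C)c4)ncc3c2)ccn1`, carries isopropyl in place of trifluoromethyl on an aromatic carbon. Going by the values given here, no measured step gives a readable size for this change, since a step that the two limits leave unreadable from compound 1 to compound 2 is hidden by the limits. For compound 3 the expected step is a step that the limit leaves unreadable from compound 2 to compound 3, with no readable direction, and the result is most likely once more a limit. The estimate for compound 3 is 500 nM, between 100 nM and 2000 nM.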

Compound 3, solubility: < 1000 nM
Compound 3 ended at the assay's limit; the forecaster's own chance of this, stated with the estimate: 85%; the middle value lies beyond the limit too.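

No step can be read among compound 1, compound 2 and compound 3, since each result is a limit of the assay and not a number: the limit of < 1000 nM in this assay, at which 3 of the 3 values shown sit.

The compounds shown leave open the true value of each one and whether tert-butyl, trifluoromethyl and isopropyl differ at all in this assay.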